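From trifluoromethyl to fluoro on a shared core

This account rests on a few compounds, and the source may have more. Where it says the series, first, only, none or still open, it means among the compounds named here.

Measured in a functional assay on HaCaT cells (Homo sapiens) for inhibition, read by sulforhodamine B assay, with a stated time of 48 h; a lower number here means a stronger inhibitor of growth, a higher number a weaker inhibitor of growth:
- Compound 1 `CC1(/C=C/c2ccccc2)C=CC(=O)O1`: 119000 nM
- Compound 2 `CC1(/C=C/c2ccc(C(F)(F)F)cc2)C=CC(=O)O1`: 12100 nM

Of these two, compound 2 has the lowest number, 12100 nM. Compound 3 `CC1(/C=C/c2ccc(F)cc2)C=CC(=O)O1` has not yet been measured. It differs from compound 2 by one change: fluoro in place of trifluoromethyl on an aromatic carbon. Within the data shown here, one measured step bears on this: a 9.8-fold lower number from compound 1 to compound 2 (0.99 log units; beyond the scatter), with trifluoromethyl in place of hydrogen on an aromatic carbon. Among the measured compounds shown here, no fluoro compound has been measured, so compound 3 is simply expected to land inside the span of the two known values, giving back part of that step in this assay. The expected change is a 3.3-fold higher number from compound 2 to compound 3 (0.52 log units; beyond the scatter), towards a higher number. Compound 3 is estimated at 40000 nM, with an expected range from 13000 nM to 120000 nM.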

Compound 3, concentration for total growth inhibition: 47500 nM
Estimate against measurement, compound 3: 1.2-fold (0.07 log units) below; the range from low to high includes it.
By their numbers in this assay, from the lowest: compound 2; then compound 3; then compound 1.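

Even a single fluoro on this aromatic carbon changes the result in this assay, with a 2.5-fold lower number from compound 1 to compound 3 (0.40 log units; beyond the scatter) beyond the usual scatter, so the gain seen with trifluoromethyl is not unique to that group. The two groups are not interchangeable, however: replacing trifluoromethyl with fluoro gives a 3.9-fold higher number from compound 2 to compound 3 (0.59 log units; beyond the scatter), so among these three compounds, fluoro falls partway between hydrogen and trifluoromethyl. No supporting measurement is available to explain this order.

A chlorine, a methoxy group or a nitrile at the same place would test whether this order extends beyond these three compounds. From the compounds shown here alone, the effect of moving fluoro or trifluoromethyl to another carbon of the ring also remains open, as every substituted compound here carries its group at the same place.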